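A few compounds are considered here, and "the series" means these few. Any claim that something is new, unique, unknown or untested is made for them only; others in the source may bear on it.

Compound 1 `OC[C@H]1O[C@@H](n2cnc3c(NCc4ccc(F)cc4)ncnc32)[C@H](O)[C@@H]1O` gives 13200 nM in a functional assay on HOS cells (Homo sapiens) for antiproliferative activity, with a stated time of 72 h; a higher number here means a weaker inhibitor, a lower number a stronger inhibitor.
Compound 2 `COc1cc(CNc2ncnc3c2ncn3[C@@H]2O[C@H](CO)[C@@H](O)[C@H]2O)cc(OC)c1` has "not determined" (no result reported) in this assay.
Compound 3 `OC[C@H]1O[C@@H](n2cnc3c(NCc4ccc(F)cc4Cl)ncnc32)[C@H](O)[C@@H]1O` reaches only > 166000 nM in this assay, which is a limit of the assay and not a number.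

Compound 1 is therefore the only one of the three with a single measured number. For the measured compounds named here, the only measured step here runs an at least 12-fold higher number from compound 1 to compound 3 (1.09 log units; beyond the scatter), a chloro in place of hydrogen on an aromatic carbon, and it ends at the limit of > 166000 nM in this assay, at which 1 of the 3 values shown sits.

Compound 4 `Cc1ccc(O)c(CNc2ncnc3c2ncn3[C@@H]2O[C@H](CO)[C@@H](O)[C@H]2O)c1` is not yet measured. It differs from compound 1 by 2-hydroxy-5-methylphenyl in place of 4-fluorophenyl on a saturated chain carbon bound to a nitrogen on an aromatic ring. No measured step bears directly on this change; the one step shown concerns a different group on the same ring and went strongly toward weaker inhibition. Given that, a modest weakening is expected rather than a gain, with the step from compound 1 estimated as a 1.7-fold higher number from compound 1 to compound 4 (0.22 log units; within the scatter). Compound 4 is accordingly estimated at 22000 nM, with a range from 6000 nM to 90000 nM.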

Compound 4, half-maximal inhibitory concentration: > 166000 nM
Compound 4: a limit, no number (the forecaster's own chance of this, stated with the estimate: 25%); at least 7.5-fold (0.87 log units) between middle value and limit.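

Replacing 4-fluorophenyl with 2-hydroxy-5-methylphenyl on this saturated chain carbon gives an at least 12-fold higher number from compound 1 to compound 4 (1.09 log units; beyond the scatter), so in this assay a second, quite different change at this position also weakens compound 1, not only the added chloro. Compound 4 gives > 166000 nM, which is a limit of the assay and not a number. The step from compound 3 to compound 4 cannot be read, and how far either compound falls stays unknown, since both end at the same limit: the limit of > 166000 nM in this assay, at which 2 of the 4 values shown sit.

Which part of the change matters stays open. The fluorine leaves as the hydroxy and methyl enter. As far as these compounds go, it is also open whether an amine or a carboxylic acid on this aromatic ring, or a longer chain carrying it, would give a measurable number.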